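A few compounds are considered here, and "the series" means these few. Any claim that something is new, unique, unknown or untested is made for them only; others in the source may bear on it.

Measured to date:
Compound 1 `O=C(NC1CCN(Cc2ccccc2)CC1)c1c(O)c2cccnc2n(-c2ccccc2)c1=O` — 1.7%
Compound 2 `O=C(NN1CCOCC1)c1c(O)c2cccnc2n(-c2ccccc2)c1=O` — -8.5%
Compound 3 `Cc1ccc(NC(=O)c2c(O)c3cccnc3n(-c3ccccc3)c2=O)cc1` — -3.5%

All three share one core and differ only in the group carried on the amide-type nitrogen. In a functional assay on the whole organism for inhibition, with Rattus norvegicus as the target, read by paw edema, at a dose of 100 mg/kg by the oral route (on this read-out higher numbers stand for more inhibition at the one dose given (going by the name of the read-out) and lower numbers for less inhibition), compound 1 gives 1.7%, compound 2 gives -8.5% and compound 3 gives -3.5%. Compound 3 stands second highest of the three numbers, but its gap to compound 2 is within the scatter and so is its gap to compound 1; none of the three can be set apart from the others, and all sit close to zero inhibition.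

The next compound is compound 4 `O=C(Nc1cccnc1)c1c(O)c2cccnc2n(-c2ccccc2)c1=O`. Relative to compound 3 the change is pyridin-3-yl in place of 4-methylphenyl on an amide-type nitrogen.

Within the data shown here, one measured step bears on this: a number 5 percentage points higher from compound 2 to compound 3 (within the scatter), which also exchanges the group on the amide-type nitrogen and is within the scatter. Among the measured compounds shown here, with the whole series flat and the only comparable exchange giving no movement beyond the scatter, no step beyond the scatter is expected in this assay from compound 3 to compound 4, in either direction.

Compound 4 is therefore expected to give about -1% in this assay, with a range from -13% to 11%, an expected step of a number 2.5 percentage points higher from compound 3 to compound 4 (within the scatter).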

Compound 4, a percentage reported as inhibition, in the whole organism at one dose (the size of the read-out at that dose, not a potency): 30.3%
Estimate against measurement, compound 4: 31.3 percentage points below; measured number above the stated range.
By their numbers in this assay, from the lowest: compounds 2, 3 and 1 (each within the scatter of the next, the first and the last beyond it); then compound 4.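

In this assay, among these compounds, the group on the amide-type nitrogen proves able to move the read-out: pyridin-3-yl in place of 4-methylphenyl gives a number 33.8 percentage points higher from compound 3 to compound 4 (beyond the scatter), where the one earlier exchange at this nitrogen stayed within the scatter. Set against morpholin-4-yl, the same pyridin-3-yl gives a number 38.8 percentage points higher from compound 2 to compound 4 (beyond the scatter), so the rise appears against two quite different leaving groups, one of them a six-membered aromatic ring of carbon only, which differs from pyridin-3-yl by the ring nitrogen, with its 1 hydrogen-bond acceptor, and by the methyl. Nothing on hand shows which part of this exchange carries the rise.

The compounds shown leave open whether the rise belongs to pyridin-3-yl alone or is shared by pyridin-2-yl, pyridin-4-yl or an unsubstituted phenyl on the same nitrogen, the last of which would separate the loss of the methyl from the entry of the ring nitrogen. They also leave open how the response of compound 4 changes at other oral doses.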